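A few compounds are considered here, and "the series" means these few. Any claim that something is new, unique, unknown or untested is made for them only; others in the source may bear on it.

Measured so far in a functional assay on PC-3 cells (Homo sapiens) for inhibition, read by MTT assay, with a stated time of 48 h, tested at 10 uM; a higher number here means more inhibition of growth at the concentration tested, a lower number less inhibition of growth:
- compound 1 `Cc1cc(=O)c2c(O)c(CN3CCC(c4ccccc4)CC3)c(O)c([C@H]3CCN(C)C[C@H]3O)c2o1`: 22%
- compound 2 `Cc1cc(=O)c2c(O)c(CN3CCCC3C(=O)O)c(O)c([C@H]3CCN(C)C[C@H]3O)c2o1`: 0%

Of these two, compound 2 stands lowest at 0%, while compound 1 sits higher at 22%, a gap beyond the usual scatter. The next compound to be tested is compound 3 `Cc1cc(=O)c2c(O)c(CN3CCCCC3)c(O)c([C@H]3CCN(C)C[C@H]3O)c2o1`. It has piperidin-1-yl in place of 2-carboxypyrrolidin-1-yl on a saturated chain carbon bound to an aromatic carbon. Among the compounds with values here, no measured pair shows what this exact swap does. Still, compound 1 also lacks 2-carboxypyrrolidin-1-yl and gives 22%, so a modest rise in this assay is expected, near the edge of the usual scatter. The estimated change is a number 12 percentage points higher from compound 2 to compound 3 (beyond the scatter). For compound 3 the expected value is 12%, with an estimated range of 0% to 30%.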

Compound 3, percent growth inhibition at one concentration: 14%
Compound 3: middle estimate off by 2 percentage points, on the low side; measured number inside the range.
By their numbers in this assay, from the lowest: compound 2; then compounds 3 and 1 (each within the scatter of the next).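

In this assay, within the data shown here, piperidin-1-yl in place of 2-carboxypyrrolidin-1-yl on a saturated chain carbon bound to an aromatic carbon gives a first direct reading at this position (a number 14 percentage points higher from compound 2 to compound 3 (beyond the scatter)), a modest step. The second step, hydrogen in place of phenyl on a saturated ring carbon (a number 8 percentage points lower from compound 1 to compound 3 (within the scatter)), leaves compound 1 and compound 3 indistinguishable in this measurement, so the phenyl group makes no difference that can be read here. Nothing measured here gives a reason for either step.

The step from 2-carboxypyrrolidin-1-yl to piperidin-1-yl changes both the ring size and the carboxylic acid, so the compounds shown cannot separate these two differences. Plain pyrrolidin-1-yl would speak to that question, while morpholin-4-yl or dimethylamino at the same place remains an open comparison.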